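Swapping the aryl group of a thiazole acylguanidine

This account rests on a few compounds, and the source may have more. Where it says the series, first, only, none or still open, it means among the compounds named here.

Measured compounds:
Compound 1 `Cc1nc(N)sc1CCCN/C(N)=N/C(=O)NC(C)c1cccc(F)c1` gives 2.04 nM.
Compound 2 `Cc1nc(N)sc1CCCN/C(N)=N/C(=O)NC(c1ccccc1)C(C)C` gives 35.5 nM.
Compound 3 `CCCCCCNC(=O)/N=C(\N)Nc1cccc(-c2csc(N)n2)c1` gives 692 nM.

The three compounds were characterised in an assay on membranes from Sf9 cells for displacement of a labelled ligand from histamine H2 receptor (Homo sapiens), read by scintillation counting, with a stated time of 60 min; on this read-out higher numbers stand for weaker inhibition and lower numbers for stronger inhibition. Compound 1 stands at the lowest number of the three, and each of its steps to the others lies beyond the scatter: the nearest is compound 2, the furthest compound 3, whose shared core differs from the other two in how the aminothiazole is joined to the acylguanidine. Compound 1 is thus the strongest inhibitor of the three.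

Compound 4 `Cc1ccc(C(C)NC(=O)/N=C(\N)NCCCc2sc(N)nc2C)cc1` has not yet been measured in this assay. It differs from compound 1 in a single place: 4-methylphenyl in place of 3-fluorophenyl on a saturated chain carbon bound to an amide-type nitrogen and a saturated chain carbon. The group that enters has the same count of heavy atoms, the same kind of ring and no donors or acceptors, just as the group that leaves. Going by the values given here, nothing among the measured compounds shows how this exchange on the aryl ring plays out, so the size of the step cannot be read off from a measured pair; the expectation is a step from compound 1 to compound 4 of a 2.0-fold higher number from compound 1 to compound 4 (0.29 log units; within the scatter), a change that may sit within the scatter or lean towards slightly weaker inhibition. For compound 4 in this assay the estimate is 4 nM, with a range from 1.5 nM to 12 nM.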

Compound 4, inhibition constant: 30.9 nM
Beside the measured number, compound 4's estimate is 7.7-fold (0.89 log units) below it; measured number outside the range, above it.
By their numbers in this assay, from the lowest: compound 1; then compounds 4 and 2 (each within the scatter of the next); then compound 3.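

In this assay, the exchange of 3-fluorophenyl for 4-methylphenyl on a saturated chain carbon bound to an amide-type nitrogen and a saturated chain carbon is far from silent: it gives a 15-fold higher number from compound 1 to compound 4 (1.18 log units; beyond the scatter), a weakening of inhibition well beyond the scatter. The earlier compounds shown here offered no single-place exchange, and this pair now shows that the aryl group at this position matters, since two groups with the same heavy-atom count, the same kind of ring and no donors or acceptors still give clearly different numbers. No measurement of any property of the two groups accompanies this step to account for it.

The two aryl groups differ both in the substituent they carry and in where it sits on the ring, so the compounds shown leave open whether the weakening follows the loss of the fluorine, the arrival of the methyl group or the change of place. A plain phenyl group or a chlorophenyl group at this position would help to separate these possibilities.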